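A few compounds are considered here, and "the series" means these few. Any claim that something is new, unique, unknown or untested is made for them only; others in the source may bear on it.

Compound 1 `C=C(C)CC1COC2(C=CC(=O)C=C2)N(c2ccccc2)C1=O` is the starting point of this step. In a functional assay on BV-2 cells (Mus musculus), read by Griess assay, with a stated time of 24 h (a lower number here means a stronger inhibitor, a higher number a weaker inhibitor), compound 1 gives 450 nM, the higher of the two numbers available, and its nearest neighbour is compound 2 `O=C1C=CC2(C=C1)OCC(Cc1ccc(F)cc1)C(=O)N2c1ccccc1`, which in this assay gives 400 nM; the change a 1.1-fold lower number from compound 1 to compound 2 (0.05 log units; within the scatter) lies within the scatter. Compound 3 `Cc1cc(C)cc(CC2COC3(C=CC(=O)C=C3)N(c3ccccc3)C2=O)c1` has not yet been measured in this assay. Its difference from compound 1 is 3,5-dimethylphenyl in place of 1-methylethenyl on a saturated chain carbon bound to a saturated ring carbon. Among the measured compounds shown here, the only measured step that bears on this change is the one from compound 1 to compound 2, in which an aromatic ring also replaced the 1-methylethenyl group at the same place and produced a 1.1-fold lower number from compound 1 to compound 2 (0.05 log units; within the scatter). On that basis compound 3 is expected to sit close to compound 1, with the step of a 1.1-fold lower number from compound 1 to compound 3 (0.05 log units; within the scatter) not going beyond the scatter in either direction. Compound 3 is therefore estimated at 400 nM, within a range from 180 nM to 900 nM.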

Compound 3, half-maximal inhibitory concentration: 1820 nM
For compound 3 the middle estimate is 4.6-fold (0.66 log units) below the measured one; the measured number lies above the stated range.
By their numbers in this assay, from the lowest: compounds 2 and 1 (each within the scatter of the next); then compound 3.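

In this assay, the place on a saturated chain carbon bound to a saturated ring carbon does not accept every aromatic group equally: 3,5-dimethylphenyl in place of 1-methylethenyl gives a 4.0-fold higher number from compound 1 to compound 3 (0.61 log units; beyond the scatter), whereas 4-fluorophenyl gave a 1.1-fold lower number from compound 1 to compound 2 (0.05 log units; within the scatter). Exchanging one aromatic group for the other gives a 4.6-fold higher number from compound 2 to compound 3 (0.66 log units; beyond the scatter), so the presence of an aromatic ring alone does not set the number here, and what that ring carries matters. No measurement at hand explains this rise.

From the compounds shown here alone, it remains open whether the higher number goes with the two methyl groups or with the absence of the fluorine. An unsubstituted phenyl group, or a ring carrying a single methyl group, would separate these two readings, and an amine at this place would show how far the tolerance extends beyond hydrocarbon groups.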